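Meta-substituent swap on the benzophenone ring: chloro to methyl

The compounds below may be only part of what the source reports. "The series", "measured", "known", "first", "only" and "open" are said of these compounds alone.

Compound 1 `CC(O)(C(=O)Nc1ccc(C(=O)c2cccc(F)c2)cc1)C(F)(F)F` is the reference point of the pair measured so far: in a functional assay (Cavia porcellus) with sulfonylurea receptors; K-ATP channels (Homo sapiens) as the target (a lower number here means a stronger inhibitor, a higher number a weaker inhibitor), compound 1 gives 2600 nM. Compound 2 `CC(O)(C(=O)Nc1ccc(C(=O)c2cccc(Cl)c2)cc1)C(F)(F)F` carries chloro in place of fluoro on an aromatic carbon. In this assay compound 2 does not reach a number but only the limit > 30000 nM. The step of an at least 11-fold higher number from compound 1 to compound 2 (1.06 log units; beyond the scatter) is therefore known only as a lower bound, because compound 2 sits at the limit of > 30000 nM in this assay, at which 1 of the 2 values shown sits.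

Compound 3 `Cc1cccc(C(=O)c2ccc(NC(=O)C(C)(O)C(F)(F)F)cc2)c1` differs from compound 2 by methyl in place of chloro on an aromatic carbon. Going by the values given here, no measured step follows this exact change; the only step in hand, from fluoro to chloro, was large and weakening. Methyl and chloro are comparable in what they add, so the expected step of an at least 1.5-fold lower number from compound 2 to compound 3 (0.17 log units; that floor lies within the scatter) is small, with compound 3 remaining far weaker than compound 1 and quite possibly again at the limit. On this basis compound 3 is estimated at 20000 nM in this assay, with a range from 5000 nM to 60000 nM.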

Compound 3, half-maximal inhibitory concentration: > 30000 nM
Compound 3: a limit, no number; the forecaster's own chance of this, stated with the estimate: 50%; middle value at least 1.5-fold (0.17 log units) from the limit.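

In this assay compound 3 gives > 30000 nM, which is a limit of the assay and not a number. Methyl in place of fluoro on this aromatic carbon gives an at least 11-fold higher number from compound 1 to compound 3 (1.06 log units; beyond the scatter), so the loss seen with chloro is not confined to chloro: of the three groups shown at this position, fluoro alone gives a measured number, and a replacement that is not a halogen ends in the same place as one that is. The step between compound 2 and compound 3 cannot be read, and no order of chloro and methyl follows from these data: the limit of > 30000 nM in this assay, at which 2 of the 3 values shown sit.

On these data alone, how far compound 2 and compound 3 lie beyond the limit remains unknown, so the size of the loss on leaving fluoro is known only as a lower bound. Also open, as far as these compounds go, is whether fluoro itself is what gives compound 1 its measured number, or whether any other group at this position would do the same: plain hydrogen, a hydroxyl, a nitrile or a methoxy group would each test this against compound 1.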